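Adding one methoxy to compound 2

The compounds below may be only part of what the source reports. "The series", "measured", "known", "first", "only" and "open" are said of these compounds alone.

Values in a functional assay on HeLa cells (Homo sapiens) for antiproliferative activity, read by sulforhodamine B assay, with a stated time of 48 h (on this read-out higher numbers stand for weaker inhibition and lower numbers for stronger inhibition), for the three measured compounds
- compound 1 `COc1cc(C(=O)/C=C\Nc2ccc(-c3nc4cc(OC)c(OC)c(OC)c4s3)cc2C)cc([N+](=O)[O-])c1OC` gives 13100 nM
- compound 2 `COc1cc(OC)c2sc(-c3ccc(N/C=C\C(=O)c4ccc(OC)c([N+](=O)[O-])c4)c(C)c3)nc2c1` gives 9390 nM
- compound 3 `COc1cc(OC)c2sc(-c3ccc(N/C=C\C(=O)c4ccc(OC)c([N+](=O)[O-])c4)cc3)nc2c1` gives 12900 nM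

Compound 2 has the lowest of these three numbers, yet both of the others lie within the usual scatter of it. All three therefore sit in one band, and the data show no real ranking among them.

Compound 4 `COc1cc(OC)c2sc(-c3ccc(N/C=C\C(=O)c4cc(OC)c(OC)c([N+](=O)[O-])c4)c(C)c3)nc2c1` is compound 2 with methoxy in place of hydrogen on an aromatic carbon and it has not yet been measured. Among the measured compounds shown here, the only measured step at a single place (a 1.4-fold higher number from compound 2 to compound 3 (0.14 log units; within the scatter)) is a different change, hydrogen in place of methyl, and it stays within the scatter. It offers only weak guidance here. Compound 1 carries the same substituted ring as compound 4 on its own core, and in this assay compound 1 gives 13100 nM which is within the scatter of the number for compound 2. Nothing measured points to a step beyond the scatter, so only a small change is expected (a 1.2-fold higher number from compound 2 to compound 4 (0.07 log units; within the scatter)) with no clear direction. Compound 4 is expected at 11000 nM and is estimated to fall from 5000 nM to 25000 nM in most repeat measurements.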

Compound 4, half-maximal inhibitory concentration: 11400 nM
For compound 4 the middle estimate is 1.0-fold (0.02 log units) below the measured one; measured number inside the range.
By their numbers in this assay, from the lowest: compounds 2, 4, 3 and 1 (each within the scatter of the next).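

In this assay, methoxy in place of hydrogen on this aromatic carbon, ortho to a methoxy group and meta to a nitro group, gives a 1.2-fold higher number from compound 2 to compound 4 (0.08 log units; within the scatter), so this position accepts the added group without a change that can be told from the scatter. Among the compounds shown here, until now, the only single-place step was hydrogen in place of methyl, at a different place, and the new pair gives the first direct reading for methoxy at this carbon. A second single-place pair, which differs by one methoxy on the core, gives a 1.1-fold lower number from compound 1 to compound 4 (0.06 log units; within the scatter), which also stays within the scatter, and no measurement is available that would explain either result.

At this position the compounds shown carry only hydrogen or methoxy, so it remains open whether a hydroxyl, an amine or a longer chain such as butoxy would move the number beyond the scatter. All four compounds also keep the nitro group, which leaves open what replacing it with an amine or a carboxylic acid would do in this assay.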